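This account rests on a few compounds, and the source may have more. Where it says the series, first, only, none or still open, it means among the compounds named here.

Compound 1: `N[C@H]1CC[C@H](Nc2c(C(=O)NCc3ccc(F)cc3)nc(N3CCCCC3)c3cccnc23)CC1`, "not determined" (no result reported)
Compound 2: `NCCCNc1c(C(=O)NCc2ccc(F)cc2)ncc2cccnc12`, > 10000 nM
Compound 3: `N[C@H]1CC[C@H](Nc2c(C(=O)NCc3ccc(F)cc3)nc(Br)c3cccnc23)CC1`, 5000 nM

Of the compounds shown here, three with a shared core have been tested in a functional assay on LNCaP cells (Homo sapiens) for cytotoxicity, read by MTT assay, with a stated time of 72 h; on this read-out lower numbers stand for stronger inhibition and higher numbers for weaker inhibition. For compound 1 the entry reads "not determined" (no result reported), so it gives no number. For compound 2 the result is a limit of the assay, > 10000 nM, and not a number; this is the limit described as the limit of > 10000 nM in this assay, at which 1 of the 3 values shown sits. For the measured compounds named here, compound 3 gives 5000 nM, which is the only actual number among the three, so it stands alone as the sole measured point of reference.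

Compound 4, `CN(C)CCCNc1c(C(=O)NCc2ccc(F)cc2)nc(Br)c2cccnc12`, has not yet been measured. Its change from compound 3 is 3-(dimethylamino)propyl in place of 4-aminocyclohexyl on a nitrogen on an aromatic ring. Going by the values given here, no measured pair here differs in just one place, so no step can be read off from the data to guide the expectation. Compound 2, which carries a chain on the same nitrogen and no bromine, sits at a limit, whereas compound 3 gives a number; that is all the two values show.

The step of a 1.6-fold higher number from compound 3 to compound 4 (0.20 log units; within the scatter) is expected to be a modest loss, possibly beyond the usual scatter. Compound 4 is estimated at 8000 nM, between 3000 nM and 20000 nM.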

Compound 4, half-maximal inhibitory concentration: 8000 nM
Compound 4: the middle estimate sits on the measured number at the digits printed, within the range that was stated.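

In this assay, placing 3-(dimethylamino)propyl where 4-aminocyclohexyl stood, on a nitrogen on an aromatic ring, gives a 1.6-fold higher number from compound 3 to compound 4 (0.20 log units; within the scatter). For the compounds shown here, this is the first pair here that differs in one place, and it shows that at this nitrogen an open chain with no ring and a six-membered carbon ring with two defined stereocentres cannot be told apart, even though the hydrogen-bond donor of the departing group is missing from the chain. Compound 2 remains a limit and not a number, and it differs from compound 3 and compound 4 in more than one place, so no step to it can be read: the limit of > 10000 nM in this assay, at which 1 of the 4 values shown sits.

The compounds shown leave open whether a longer chain, such as 4-(dimethylamino)butyl, or a chain ending in a carboxylic acid would read differently on this nitrogen. Going by these compounds alone, no pair here differs only at the bromine, so its part also stays open.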